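Moving the fluorine around the pendant phenyl ring

The compounds below may be only part of what the source reports. "The series", "measured", "known", "first", "only" and "open" are said of these compounds alone.

Compound 3 `Oc1cccc(-c2cc(-c3cccc(F)c3)cc(-c3ccccc3O)n2)c1` carries a 3-fluorophenyl group on the shared core. In a functional assay on T47D cells (Homo sapiens) for inhibition (a higher number here means a weaker inhibitor, a lower number a stronger inhibitor), compound 3 gives > 50000 nM, which is a limit of the assay and not a number. Compound 2 `Oc1cccc(-c2cc(-c3ccccc3F)cc(-c3ccccc3O)n2)c1` differs only in its 2-fluorophenyl group, and in this assay compound 2 gives 24200 nM. Among the compounds with values here, the step of an at least 2.0-fold higher number from compound 2 to compound 3 (0.31 log units; beyond the scatter) is therefore the one measured change among the three compounds that moves the fluorine from one position of that ring to another. Compound 1 `Oc1ccccc1-c1cc(-c2ccc(F)cc2)cc(-c2ccccc2O)n1` also carries a 4-fluorophenyl group, but with two 2-hydroxyphenyl groups on the core. In this assay compound 1 gives > 50000 nM, a limit of the assay.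

Compound 4 `Oc1cccc(-c2cc(-c3ccc(F)cc3)cc(-c3ccccc3O)n2)c1` is not yet measured. The change is 4-fluorophenyl in place of 3-fluorophenyl on an aromatic carbon. Within the data shown here, no measured step reports this exact change; the nearest evidence is the limit of > 50000 nM in this assay, at which 2 of the 3 values shown sit, with compound 3 sitting at that limit already. Given that the one positional change measured, from compound 2 to compound 3, weakened inhibition, and that compound 1 with the same 4-fluorophenyl group also sits at the limit, compound 4 is expected to stay at or beyond the limit, a step that the limit leaves unreadable from compound 3 to compound 4. The estimate for compound 4 in this assay is 70000 nM, with a range from 20000 nM to 250000 nM.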

Compound 4, half-maximal inhibitory concentration: > 50000 nM
Compound 4 was reported as a limit; the forecaster's own chance of this, stated with the estimate: 75%; the middle value does not contradict the limit.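

With the 4-fluorophenyl group in place of the 2-fluorophenyl group on the shared core, this assay shows an at least 2.0-fold higher number from compound 2 to compound 4 (0.31 log units; beyond the scatter), and this joins the earlier at least 2.0-fold higher number from compound 2 to compound 3 (0.31 log units; beyond the scatter). Of the three fluorine placements on this ring, only the 2-fluorophenyl group of compound 2 therefore gives a readable value, 24200 nM, and both other placements lie beyond the scatter on the weaker side of it. The steps between compound 3 and compound 4 and between compound 1 and compound 4 cannot be read, so neither the shift from 3-fluorophenyl to 4-fluorophenyl nor the shift from 2-hydroxyphenyl to 3-hydroxyphenyl has a size, and most of the series rests on the same assay limit: the limit of > 50000 nM in this assay, at which 3 of the 4 values shown sit.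

From the compounds shown here alone, whether the fluorine itself contributes to the value of compound 2 stays open, and a plain phenyl group at this position would be the direct comparison. Going by these compounds, it also stays open whether a 2-aminophenyl or 2-carboxyphenyl group at this position would keep a readable value or improve on compound 2.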